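A Chloro in Place of Fluoro on Compound 2

This account rests on a few compounds, and the source may have more. Where it says the series, first, only, none or still open, it means among the compounds named here.

In an ADME assay on the whole organism (blood, Mus musculus, strain C57BL/6) for pharmacokinetics, read by HPLC, with a stated time of 4 h, at a dose of 2 mg/kg by the intraperitoneal route (a higher number here means more compound in the circulation at the dose given, a lower number less compound in the circulation), compound 2 `CC(C)S(=O)(=O)c1c(Cl)ccc(NC(=O)Nc2cccc(F)c2Cl)c1O` gives 198 ng.h/mL and compound 1 `CN1CCN(S(=O)(=O)c2c(Cl)ccc(NC(=O)Nc3cccc(Cl)c3Cl)c2O)CC1` gives 303 ng.h/mL. Going by the values given here, these two numbers lie within the usual scatter of each other, so compound 2 stands level with the only other compound measured. The two differ in more than one place, which leaves no measured single change to serve as a guide.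

Compound 3 `CC(C)S(=O)(=O)c1c(Cl)ccc(NC(=O)Nc2cccc(Cl)c2Cl)c1O` differs from compound 2 in one place: chloro in place of fluoro on an aromatic carbon. This turns 2-chloro-3-fluorophenyl into 2,3-dichlorophenyl, the group also carried by compound 1, which gives 303 ng.h/mL. In this assay, no step beyond the scatter is expected. The estimated step of a 1.2-fold higher number from compound 2 to compound 3 (0.07 log units; within the scatter) is small and stays within that scatter. The estimate for compound 3 is 230 ng.h/mL, with an expected range of 100 ng.h/mL to 520 ng.h/mL.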

Compound 3, area under the concentration-time curve: 290 ng.h/mL
The estimate for compound 3 lay 1.3-fold (0.10 log units) below the measured number; the measured number falls inside the stated range.
By their numbers in this assay, from the lowest: compounds 2, 3 and 1 (each within the scatter of the next).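

Chloro in place of fluoro on an aromatic carbon, which turns 2-chloro-3-fluorophenyl into 2,3-dichlorophenyl, gives a 1.5-fold higher number from compound 2 to compound 3 (0.17 log units; within the scatter) in this assay, so compound 2 and compound 3 stand level. A second single change can now be read as well: isopropyl in place of 4-methylpiperazin-1-yl on a sulfonyl sulfur gives a 1.0-fold lower number from compound 1 to compound 3 (0.02 log units; within the scatter), so with the 2,3-dichlorophenyl group held in common, these two compounds also stand level. Nothing at hand explains why either exchange leaves the numbers level.

The compounds shown cover only these two exchanges, so it stays open whether any group at either place would shift the number beyond the scatter. A methoxy group or a nitrile on that aromatic carbon, or a carboxylic acid or a longer chain on the sulfonyl sulfur, would test this.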